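Swapping the Thiocarbonyl Amine on a Chromone Dithiocarbamate

A few compounds are considered here, and "the series" means these few. Any claim that something is new, unique, unknown or untested is made for them only; others in the source may bear on it.

Measured so far:
compound 1 `CC(C)N(C(=S)SCc1cc(=O)c2ccc(Cl)cc2o1)C(C)C`, > 25000 nM in a functional assay on SW480 cells (Homo sapiens) for antiproliferative activity, read by MTT assay, with a stated time of 72 h; on this read-out higher numbers stand for weaker inhibition and lower numbers for stronger inhibition
compound 2 `O=c1cc(CSC(=S)N2CCOCC2)oc2cc(Cl)ccc12`, > 25000 nM
compound 3 `O=c1c(CSC(=S)N2CCOCC2)coc2ccccc12`, 5900 nM

The value of compound 1 is a limit of this assay, not a number. The value of compound 2 is likewise a limit. Within the data shown here, compound 3 gives the only number here; this is the position described by the limit of > 25000 nM in this assay, at which 2 of the 3 values shown sit. From compound 2 to compound 1 the change is diisopropylamino in place of morpholin-4-yl on a thiocarbonyl carbon, and the step that the two limits leave unreadable from compound 2 to compound 1 cannot be read. The difference between the cores of compound 2 and compound 3 is not broken down here. Compound 4 `CC(C)N(C(=S)SCc1coc2ccccc2c1=O)C(C)C` carries the same change on the core of compound 3: diisopropylamino in place of morpholin-4-yl on a thiocarbonyl carbon. Because the step that the two limits leave unreadable from compound 2 to compound 1 gives no readable size, the expected step of a 2.0-fold higher number from compound 3 to compound 4 (0.31 log units; beyond the scatter) rests only on compound 3 at 5900 nM, and for compound 4 the estimate is 12000 nM, between 3000 nM and 40000 nM.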

Compound 4, half-maximal inhibitory concentration: 6800 nM
Estimate against measurement, compound 4: 1.8-fold (0.25 log units) above, and the stated range covers the measured number.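

In this assay, diisopropylamino in place of morpholin-4-yl on a thiocarbonyl carbon gives a 1.2-fold higher number from compound 3 to compound 4 (0.06 log units; within the scatter), so the two groups cannot be told apart on this core. This is a single pair on a single core, and it does not show that the change behaves the same way on another core. The matching step on the core of compound 2 cannot be read, because the values of compound 1 and compound 2 are both limits of the assay, not numbers: the limit of > 25000 nM in this assay, at which 2 of the 4 values shown sit.

Still open, going by these compounds, is whether a different amine on the thiocarbonyl carbon, such as dimethylamino or piperidin-1-yl, would move the number beyond the scatter on the core of compound 3. On these data alone, it is also open whether any amine would bring the core of compound 2 to a readable number.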